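A few compounds are considered here, and "the series" means these few. Any claim that something is new, unique, unknown or untested is made for them only; others in the source may bear on it.

Of the compounds shown here, two that share one core have been measured in an assay on isolated protein (Oryctolagus cuniculus) with Thromboxane-A synthase (Homo sapiens) as the target, tested at 1 uM; on this read-out lower numbers stand for less inhibition and higher numbers for more inhibition at the one concentration tested (going by the name of the read-out). Compound 1, `COCCn1nc(-c2cccnc2)c2ccccc2c1=O`, carries a methoxy group on a saturated chain carbon, two bonds along the chain from an aromatic nitrogen; in this assay compound 1 gives 55%. Compound 2, `O=c1c2ccccc2c(-c2cccnc2)nn1CCSc1ncccn1`, keeps everything else and puts a (pyrimidin-2-yl)sulfanyl group in place of that methoxy; in this assay compound 2 gives 86%, the higher of the two numbers, and the step of a number 31 percentage points higher from compound 1 to compound 2 (beyond the scatter) lies well beyond the scatter. Compound 3, `CC(C)NC(=O)CCCn1nc(-c2cccnc2)c2ccccc2c1=O`, varies the same place once more: (isopropylcarbamoyl)methyl in place of (pyrimidin-2-yl)sulfanyl on a saturated chain carbon, two bonds along the chain from an aromatic nitrogen. Among the compounds with values here, only one measured step bears on this change, a number 31 percentage points higher from compound 1 to compound 2 (beyond the scatter), and it shows that the group at this place can move the number a long way. Within the data shown here, the group that enters in compound 3 has no measured counterpart in this set, so its own effect is open; what is known is that the group which came with the large gain is leaving. Because that gain a number 31 percentage points higher from compound 1 to compound 2 (beyond the scatter) rested on the departing group, a downward step of uncertain size is expected for compound 3, a number 31 percentage points lower from compound 2 to compound 3 (beyond the scatter). Compound 3 is estimated to give 55%, with a range from 30% to 78%.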

Compound 3, a percentage reported as inhibition, at one concentration (the size of the read-out at that concentration, not a potency): 89%
Compound 3: middle estimate off by 34 percentage points, on the low side; measured number above the stated range.
By their numbers in this assay, from the lowest: compound 1; then compounds 2 and 3 (each within the scatter of the next).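

In this assay, replacing (pyrimidin-2-yl)sulfanyl with (isopropylcarbamoyl)methyl gives a number 3 percentage points higher from compound 2 to compound 3 (within the scatter), so the two groups cannot be told apart at this place on a saturated chain carbon, even though one contains an aromatic ring and the other has no ring. The high number therefore does not depend on the (pyrimidin-2-yl)sulfanyl group alone: the step from methoxy to (isopropylcarbamoyl)methyl is a number 34 percentage points higher from compound 1 to compound 3 (beyond the scatter), a large gain like the one seen earlier with the ring-bearing group, and among these three compounds only methoxy, in compound 1, stands apart. Nothing measured here bears on the reason for this result.

As far as these compounds go, it remains open whether a carboxylic acid or a simple amine at the end of the chain would also reach the level of compound 2 and compound 3, and whether a shorter or longer chain carrying the same amide would do so. The read-out also comes from a single concentration and is not a potency, so a full concentration series could still separate compound 2 from compound 3.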